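A few compounds are considered here, and "the series" means these few. Any claim that something is new, unique, unknown or untested is made for them only; others in the source may bear on it.

Compound 1, `Cn1c(C(=O)NCc2ccc(S(=O)(=O)c3ccccc3)cc2)cc2cnccc21`: > 10000 nM
Compound 2, `O=C(NCc1ccc(S(=O)(=O)c2ccccc2)cc1)c1cc2ncccc2s1`: > 10000 nM
Compound 3, `Cc1cccc(S(=O)(=O)c2ccc(CNC(=O)c3cc4cnccc4[nH]3)cc2)c1`: 4 nM

These three compounds were tested in a functional assay on A2780 cells (Homo sapiens) for inhibition, read by sulforhodamine B assay, with a stated time of 72 h; on this read-out lower numbers stand for stronger inhibition and higher numbers for weaker inhibition. For compound 1 the value > 10000 nM is a limit of the assay, not a number. For compound 2 the value > 10000 nM is likewise only a limit. Compound 3, which carries a different bicyclic amide part and a methyl group on its sulfonyl phenyl ring, gives a real number, 4 nM. So compound 2 stands at the weak end of what has been seen: the limit of > 10000 nM in this assay, at which 2 of the 3 values shown sit.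

The next compound, compound 4 with the structure `O=C(NCc1ccc(S(=O)(=O)c2ccccc2)cc1)c1cc2ccncc2s1`, has not yet been measured. It differs from compound 2 only in the bicyclic group on the carbonyl carbon: a group of 9 heavy atoms (7 carbon, 1 nitrogen, 1 sulfur; one five-membered aromatic ring with 1 hetero atom, one six-membered aromatic ring with 1 hetero atom) in place of a group of 9 heavy atoms (7 carbon, 1 nitrogen, 1 sulfur; one five-membered aromatic ring with 1 hetero atom, one six-membered aromatic ring with 1 hetero atom), on a carbonyl carbon. The same atoms are present, joined differently. Among the measured compounds shown here, no pair of measured compounds differs in one place, so no measured step guides this change. Since the group keeps its size, its ring pattern and its hydrogen-bond count, the expectation is a step of about zero beyond the scatter, with compound 4 most likely remaining at the limit. Compound 4 is therefore estimated at 10000 nM, with a range from 2000 nM to 30000 nM. This expected change from compound 2 corresponds to a number no higher from compound 2 to compound 4 (the limit leaves the size open).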

Compound 4, half-maximal inhibitory concentration: 14 nM
Estimate against measurement, compound 4: 710-fold (2.85 log units) above; measured number outside the range, below it.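

In this assay, moving the same atoms into a different arrangement within the bicyclic group on the carbonyl carbon gives an at least 710-fold lower number from compound 2 to compound 4 (2.85 log units; beyond the scatter). Compound 2 gives only a limit, not a number, and it stands at the weak end of what is shown: the limit of > 10000 nM in this assay, at which 2 of the 4 values shown sit.
The two groups match in heavy atoms, rings, hydrogen-bond donors and acceptors and charge, so these counts alone do not tell an inactive group from an active one at this place, and the way the atoms are joined can decide the result.

The compounds shown do not reveal why this rearrangement matters so much, nor how the nitrogen and sulfur each contribute, since a single pair cannot separate the two. They also leave open whether the number of compound 4 would hold with an oxygen in place of the sulfur in the five-membered ring, or with an amine or a carboxylic acid added to the bicyclic group.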